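The source may report more compounds than this note shows. Statements on the series, on what has been measured and on what is new or still open speak of the compounds shown alone.

Measured in a functional assay on HL-60 cells (Homo sapiens) for cytotoxicity, read by MTT assay, with a stated time of 72 h; a higher number here means a weaker inhibitor, a lower number a stronger inhibitor:

- compound 1 `CCOC(=O)c1sc2ccccc2c1Nc1cc(OC)c(OC)c(OC)c1`: 5490 nM
- compound 2 `CCOC(=O)c1sc2cccc(C)c2c1Nc1cc(OC)c(OC)c(OC)c1`: 7390 nM
- compound 3 `COC(=O)c1sc2ccccc2c1Nc1cc(OC)c(OC)c(OC)c1`: 1540 nM

Compound 1 stands in the upper pair of these three numbers. Its nearest neighbour is reached by a 1.3-fold higher number from compound 1 to compound 2 (0.13 log units; within the scatter), and its furthest by a 3.6-fold lower number from compound 1 to compound 3 (0.55 log units; beyond the scatter).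

The next compound to be read is compound 4 `CCOC(=O)c1sc2cc(OC)ccc2c1Nc1cc(OC)c(OC)c(OC)c1`. It departs from compound 1 by one change, (methoxy in place of hydrogen on an aromatic carbon), which places methoxy in place of hydrogen on an aromatic carbon of a six-membered aromatic ring of carbon only.

Of the two measured steps, the methyl step bears most directly, since it too replaces hydrogen on an aromatic carbon. That step is a 1.3-fold higher number from compound 1 to compound 2 (0.13 log units; within the scatter). The other step, a 3.6-fold lower number from compound 1 to compound 3 (0.55 log units; beyond the scatter), is larger, but it concerns a saturated chain carbon bound to an oxygen and says little about this change. Among the compounds with values here, no methoxy compound has yet been measured, so the guidance rests on a single substitution, and a shift in either direction remains possible. No change beyond the scatter is therefore expected in this assay. The expected change is a 1.4-fold lower number from compound 1 to compound 4 (0.14 log units; within the scatter).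

For compound 4, the estimated value is 4000 nM, with an expected range from 900 nM to 11000 nM.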

Compound 4, half-maximal inhibitory concentration: 31.6 nM
Compound 4: the middle estimate sits 130-fold (2.10 log units) above what was measured; the measured number lies below the stated range.
By their numbers in this assay, from the lowest: compound 4; then compound 3; then compounds 1 and 2 (each within the scatter of the next).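

In this assay, within the data shown here, the step of a 170-fold lower number from compound 1 to compound 4 (2.24 log units; beyond the scatter) shows that this position, on an aromatic carbon of a six-membered aromatic ring of carbon only, meta to a fused ring and para to a fused ring, can carry a change that matters far more than anything the earlier compounds revealed. Neither the methyl step a 1.3-fold higher number from compound 1 to compound 2 (0.13 log units; within the scatter) nor the change on the saturated chain carbon bound to an oxygen a 3.6-fold lower number from compound 1 to compound 3 (0.55 log units; beyond the scatter) came close in size, so the methyl result gave no hint that an aromatic hydrogen of this ring could be so consequential. Nothing available accounts for the size of this step.

Compound 2 and compound 4 differ in both the group and the carbon that carries it, so the compounds shown do not separate the contribution of methoxy itself from that of its place, a question that a hydroxy group, an ethoxy group or a fluorine on the same carbon would address. As far as these compounds go, it also remains open whether the methoxy change and the change seen in compound 3 would add up when combined in one compound.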